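A few compounds are considered here, and "the series" means these few. Any claim that something is new, unique, unknown or untested is made for them only; others in the source may bear on it.

Measured in an assay on isolated protein (Cricetulus griseus) for binding affinity to Alpha-1B adrenergic receptor (Mesocricetus auratus), read by radioligand binding (on this read-out higher numbers stand for weaker inhibition and lower numbers for stronger inhibition), each value being a limit of the assay rather than a number:
compound 1 `CN(c1cccc2c1CCCC2c1c[nH]cn1)S(C)(=O)=O`: < 10000 nM
compound 2 `O=S(=O)(Nc1cccc2c1CCCC2c1c[nH]cn1)C1CC1`: < 10000 nM
compound 3 `CCS(=O)(=O)Nc1cc(F)cc2c1CCCC2c1c[nH]cn1`: < 10000 nM

Compound 3 thus stands only at a limit in this assay, as do the other two values shown, all three sitting at the limit of < 10000 nM in this assay, at which 3 of the 3 values shown sit. Compound 4 `CCS(=O)(=O)Nc1cc(C2CCCCC2)cc2c1CCCC2c1c[nH]cn1` differs from compound 3 by cyclohexyl in place of fluoro on an aromatic carbon. Going by the values given here, the only measured step, a step that the two limits leave unreadable from compound 1 to compound 2, changes a different group and its size cannot be read from the two limits, so it offers no direction for this replacement. No change beyond the scatter is therefore expected in this assay. The estimate for compound 4 is 2000 nM, with a range from 200 nM to 10000 nM. The step implied by this estimate is expected to be a step that the limit leaves unreadable from compound 3 to compound 4.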

Compound 4, inhibition constant: 891 nM
The estimate for compound 4 lay 2.2-fold (0.35 log units) above the measured number; low and high end bracket the measured number.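

No step can be read between compound 3 and compound 4. In this assay compound 3 gives < 10000 nM, which is a limit of the assay. The compounds shown leave open how far cyclohexyl in place of fluoro shifts the binding affinity.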